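A few compounds are considered here, and "the series" means these few. Any claim that something is new, unique, unknown or untested is made for them only; others in the source may bear on it.

Measured so far in a functional assay on the whole organism (strain Wistar albino) for inhibition, with Rattus norvegicus as the target, read by paw edema, with stated times of 30 min and 5 h, at a dose of 0.05 mmol/kg; a lower number here means less inhibition, a higher number more inhibition at the dose given (going by the name of the read-out):
compound 1, `COc1ccc([C@@H]2CC(c3cccc(O)c3)=NN2c2ccc(S(N)(=O)=O)cc2)cc1`: 62.9%
compound 2, `Cc1ccc([C@@H]2CC(c3cccc(O)c3)=NN2c2ccc(S(N)(=O)=O)cc2)cc1`: 66%

Going by the values given here, compound 2 cannot be set apart from compound 1 on these numbers, since the only step between them, a number 3.1 percentage points higher from compound 1 to compound 2 (within the scatter), lies within the scatter of this assay. The unmeasured compound 3, `NS(=O)(=O)c1ccc(N2N=C(c3cccc(O)c3)C[C@H]2c2ccc(O)cc2)cc1`, differs from compound 2 in one place: hydroxy in place of methyl on an aromatic carbon. Among the compounds with values here, the sole measured step, methyl in place of methoxy on an aromatic carbon, bears on this only loosely, as hydroxy has not yet been placed at that position; that step was small. With no evidence of a large effect at this position, compound 3 is expected to give a value close to that of compound 2, with an expected step of a number 3 percentage points lower from compound 2 to compound 3 (within the scatter) in this assay. Compound 3 is therefore estimated at 63%, within a range of 50% to 76%, in this assay.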

Compound 3, a percentage reported as inhibition, in the whole organism at one dose (the size of the read-out at that dose, not a potency): 77.7%
Compound 3: the middle estimate sits 14.7 percentage points below what was measured; the whole stated range lies below it.
By their numbers in this assay, from the lowest: compounds 1 and 2 (each within the scatter of the next); then compound 3.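

In this assay, going by these compounds alone, this position para to a large group turns out not to be indifferent to what sits on it: hydroxy in place of methyl gives a number 11.7 percentage points higher from compound 2 to compound 3 (beyond the scatter) and is the first change to go beyond the scatter. Taking the methyl off the oxygen of the methoxy group gives a number 14.8 percentage points higher from compound 1 to compound 3 (beyond the scatter) as well, so compound 3 stands apart from both compound 1 and compound 2, which cannot be told apart from each other. No measurement at hand explains why the free hydroxy differs from these two groups.

From the compounds shown here alone, whether an amine or a carboxylic acid at this position would read like hydroxy or like methyl remains open. So does whether the gain seen at this single dose would hold at other doses.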